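Adding a Hydroxy Group to Compound 2

The compounds below may be only part of what the source reports. "The series", "measured", "known", "first", "only" and "open" are said of these compounds alone.

Compound 1, `Oc1cccc(-c2ccc3c(-c4ccc5[nH]ccc5c4)c(O)ccc3c2)c1`: 87% in an assay for binding affinity to 17-beta-hydroxysteroid dehydrogenase type 1 (Homo sapiens), read by scintillation counting, with a stated time of 10 min, tested at 1 uM; a higher number here means more inhibition at the concentration tested (going by the name of the read-out), a lower number less inhibition.
Compound 2, `Oc1ccccc1-c1ccc2c(-c3cncnc3)cccc2c1`: < 10% in this assay, a limit of the assay and not a number.
Compound 3, `Oc1cccc(-c2ccc3c(-c4cncnc4)cccc3c2)c1`: < 10% in this assay, also a limit rather than a number.

Compound 2 therefore stands at the lower edge of what this assay reports, and one other measured compound sits there too. The step that the two limits leave unreadable from compound 2 to compound 3 cannot be read because the limit of < 10% in this assay, at which 2 of the 3 values shown sit, means neither end of it is a number.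

Compound 4, `Oc1ccccc1-c1ccc2c(-c3cncnc3)c(O)ccc2c1`, differs from compound 2 by hydroxy in place of hydrogen on an aromatic carbon. Within the data shown here, no measured step carries this same change, so there is no direct guide to its size. Compound 1 does carry a hydroxy on its core and gives a high value, but it differs from compound 4 in other places as well, so its value is only a loose hint. The step from compound 2 to compound 4 is therefore expected to be modest and upward, as a number at least 20 percentage points higher from compound 2 to compound 4 (beyond the scatter). Compound 4 is estimated to give 30%, within a range from 5% to 65%.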

Compound 4, a percentage reported as inhibition, at one concentration (the size of the read-out at that concentration, not a potency): < 10%
Compound 4 ended at the assay's limit; the forecaster's own chance of this, stated with the estimate: 35%; at least 20 percentage points between middle value and limit.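

The step between compound 2 and compound 4 cannot be read, since each of the two compounds rests at a limit and not at a number: the limit of < 10% in this assay, at which 3 of the 4 values shown sit. The compounds shown leave open whether hydroxy in place of hydrogen on this aromatic carbon changes inhibition at all in this assay.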